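The compounds below may be only part of what the source reports. "The series", "measured", "known", "first", "only" and "open" are said of these compounds alone.

Compound 3, with the structure `CN1CC2(CCN(c3ccc(OCc4ccccc4)c(C(=O)Nc4ccnnc4)c3)CC2)C1`, gives 2.2 in a physicochemical assay for lipophilicity, at pH 7.4; on this read-out higher numbers stand for higher lipophilicity and lower numbers for lower lipophilicity. Among the three measured compounds it holds the lowest number: the nearest is compound 2, with the structure `O=C(Nc1ccnnc1)c1cc(N2CCC(CO)CC2)ccc1OCc1ccccc1`, at 3.5, and the furthest is compound 1, with the structure `O=C(Nc1ccnnc1)c1cc(N2CCC(F)CC2)ccc1OCc1ccccc1`, at 5.1.

Compound 4, with the structure `C[C@@H]1CN(c2ccc(OCc3ccccc3)c(C(=O)Nc3ccnnc3)c2)C[C@H](C)O1`, is not yet measured. It differs from compound 3 in one place: a group of 8 heavy atoms (6 carbon, 1 nitrogen, 1 oxygen; one six-membered non-aromatic ring with 2 hetero atoms) in place of a group of 10 heavy atoms (8 carbon, 2 nitrogen; one four-membered non-aromatic ring with 1 hetero atom, one six-membered non-aromatic ring with 1 hetero atom), on an aromatic carbon.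

Among the compounds with values here, two measured steps bear on this change, since both end in the group that now leaves. The step of a number 2.90 log units lower from compound 1 to compound 3 (beyond the scatter) and the step of a number 1.30 log units lower from compound 2 to compound 3 (beyond the scatter) show that bringing in this leaving group lowered the number in this assay strongly in both cases. Removing it again in favour of the 2,6-dimethylmorpholin-4-yl group, a six-membered ring with two hetero atoms and no hydrogen-bond donors, is therefore expected to move the number back upward by a large step, though how far is uncertain because the entering group is not the same as in compound 1 or compound 2.

For compound 4 a rise of a number 2.00 log units higher from compound 3 to compound 4 (beyond the scatter) is expected. In this assay compound 4 is estimated at 4.2, within a range from 3.5 to 4.9.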

Compound 4, distribution coefficient: 5.4
Compound 4: the middle estimate sits 1.20 log units below what was measured, outside the stated range (above it).
By their numbers in this assay, from the lowest: compound 3; then compound 2; then compounds 1 and 4 (each within the scatter of the next).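

At this aromatic carbon, meta to the (pyridazin-4-yl)carbamoyl group and para to the benzyloxy group, this assay shows a number 3.20 log units higher from compound 3 to compound 4 (beyond the scatter) when 2,6-dimethylmorpholin-4-yl replaces the group of compound 3, even though the two groups have the same counts of hydrogen-bond donors and acceptors and neither carries a net charge, so those counts alone do not sort the numbers at this position. The same entering group gives a number 1.90 log units higher from compound 2 to compound 4 (beyond the scatter) in place of 4-(hydroxymethyl)piperidin-1-yl, which places a second ring without a hydroxyl group well away from the low end of the series. Against 4-fluoropiperidin-1-yl the result is a number 0.30 log units higher from compound 1 to compound 4 (within the scatter), so these two groups cannot be told apart on this read-out, despite their different ring atoms and substituents.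

The compounds shown leave open how much the two methyl groups contribute, which a plain morpholin-4-yl group would test, and whether a 4-methylpiperazin-1-yl group, with its ring amine, would fall near compound 3 or near compound 4. Nothing available here accounts for the size of these steps.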